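A few compounds are considered here, and "the series" means these few. Any claim that something is new, unique, unknown or untested is made for them only; others in the source may bear on it.

Compound 1 `CC1(C)O[C@@H](CO)[C@H](Cn2cc(Cn3c4c(c5ccccc53)C(=O)c3c[n+]([O-])c5ccccc5c3C4=O)nn2)O1`: 120 nM
Compound 2 `O=C1c2c[n+]([O-])c3ccccc3c2C(=O)c2c1c1ccccc1n2Cc1cn([C@@H]2C[C@H](O)[C@@H](CO)O2)nn1`: 820 nM
Compound 3 `O=C1c2c[n+]([O-])c3ccccc3c2C(=O)c2c1c1ccccc1n2CCCN1CCC(O)CC1`: 170 nM

In a toxicity assay on HEK-293T cells (Homo sapiens) for cytotoxicity, read by MTT assay, with a stated time of 72 h (a lower number here means a stronger inhibitor, a higher number a weaker inhibitor), compound 3 stands second highest of the three numbers: its value lies within the scatter of compound 1, and the gap to compound 2 is beyond the scatter. Compound 4 `O=C1c2c[n+]([O-])c3ccccc3c2C(=O)c2c1c1ccccc1n2Cc1cn(C[C@H](O)CO)nn1` differs from compound 3 by 1-(2,3-dihydroxypropyl)-1H-1,2,3-triazol-4-yl in place of 2-(4-hydroxypiperidin-1-yl)ethyl on a saturated chain carbon bound to an aromatic nitrogen. Going by the values given here, no measured step covers this change directly. Among the compounds with values here, the only measured step, a 6.8-fold higher number from compound 1 to compound 2 (0.83 log units; beyond the scatter), shows that exchanging the group on an aromatic nitrogen of the same triazole can move the number beyond the scatter, and compound 2, the measured compound with free hydroxyls, carries the highest number. For compound 4 a modest step upward is therefore expected, a 2.4-fold higher number from compound 3 to compound 4 (0.37 log units; beyond the scatter). For compound 4 the estimate is 400 nM, range 150 nM to 1100 nM.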

Compound 4, half-maximal inhibitory concentration: 8880 nM
Compound 4: middle estimate off by 22-fold (1.35 log units), on the low side; the whole stated range lies below it.
By their numbers in this assay, from the lowest: compounds 1 and 3 (each within the scatter of the next); then compound 2; then compound 4.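

In this assay, going by these compounds alone, every compound so far carries a free hydroxyl, yet the open 2,3-dihydroxypropyl in place of 4-hydroxy-5-(hydroxymethyl)oxolan-2-yl on an aromatic nitrogen gives an 11-fold higher number from compound 2 to compound 4 (1.03 log units; beyond the scatter), so a free hydroxyl alone does not set the number. Within the data shown here, this position also spans far more than the earlier compounds showed, with a 52-fold higher number from compound 3 to compound 4 (1.72 log units; beyond the scatter) and a 74-fold higher number from compound 1 to compound 4 (1.87 log units; beyond the scatter). Nothing available accounts for these steps.

As far as these compounds go, it remains open whether the rise follows the triazole or the diol chain: a butyl chain on the same triazole would help separate the two.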